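Swapping Isobutyl for a Furan Ring on a Shared Core

A few compounds are considered here, and "the series" means these few. Any claim that something is new, unique, unknown or untested is made for them only; others in the source may bear on it.

Of the compounds shown here, three with a shared core have been measured in a physicochemical assay for acid dissociation. Compound 1 `CCN(C1=NCCN1)c1c(Br)cccc1Br` gives 11.1, compound 2 `CC(C)CCN(C1=NCCN1)c1c(Br)cccc1Br` gives 10.9, and compound 3 `Brc1cccc(Br)c1N(CC1CCCCC1)C1=NCCN1` gives 11.2. Compound 2 holds the lowest of the three numbers, yet its gaps to compound 1 and to compound 3 both lie within the scatter. Compound 4 `Brc1cccc(Br)c1N(Cc1ccco1)C1=NCCN1` differs from compound 2 in one place: furan-2-yl in place of isobutyl on a saturated chain carbon bound to a nitrogen on an aromatic ring. The measured step closest in kind, made at the same place, was a number 0.30 log units higher from compound 2 to compound 3 (within the scatter); the others, a number 0.20 log units lower from compound 1 to compound 2 (within the scatter) and a number 0.10 log units higher from compound 1 to compound 3 (within the scatter), were likewise within the scatter. With every known step that small, no change beyond the scatter in this assay is expected, so the expected step is a number 0.10 log units higher from compound 2 to compound 4 (within the scatter). Compound 4 is therefore estimated at 11, between 10.4 and 11.6.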

Compound 4, acid dissociation constant: 10.5
The estimate for compound 4 lay 0.50 log units above the measured number, and the stated range covers the measured number.
By their numbers in this assay, from the lowest: compound 4; then compounds 2, 1 and 3 (each within the scatter of the next).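

Among the compounds shown here, at this place, on a saturated chain carbon bound to a nitrogen on an aromatic ring, furan-2-yl is the first group to move the number in this assay beyond the scatter. Against each earlier group the change reads the same way: a number 0.40 log units lower from compound 2 to compound 4 (beyond the scatter) and a number 0.70 log units lower from compound 3 to compound 4 (beyond the scatter) and a number 0.60 log units lower from compound 1 to compound 4 (beyond the scatter). So this place does respond to some changes, although methyl, isobutyl and cyclohexyl stayed within the scatter of one another. Nothing available explains the shift. Still open, from the compounds shown here alone, is whether a phenyl or thiophene ring here would give the same result.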